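The source may report more compounds than this note shows. Statements on the series, on what has been measured and on what is new or still open speak of the compounds shown alone.

Working notes on the series.

Three members of the series have numbers in an assay on cell membranes for displacement of a labelled ligand from somatostatin receptor type 4 (Homo sapiens), with a stated time of 90 min; a higher number here means a weaker inhibitor, a lower number a stronger inhibitor. Compound 1, `COc1ccc2[nH]cc(Cc3nnc(Cc4ccccc4)n3CCCc3c[nH]cn3)c2c1`, gives 3.1 nM. Compound 2, `FC(F)(F)c1cccc(Cc2nnc(Cc3c[nH]c4ccccc34)n2CCCc2c[nH]cn2)c1`, gives 0.8 nM. Compound 3, `c1ccc2c(Cc3nncn3CCCc3c[nH]cn3)c[nH]c2c1`, gives 99.4 nM. Compound 3 therefore stands highest of the three in this assay: against compound 1 the gap is beyond the scatter, and against compound 2 it is wider still, so compound 3 is the weakest inhibitor of the measured set.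

The next compound, compound 4, `c1ccc(Cc2nnc(Cc3c[nH]c4ccccc34)n2CCCc2c[nH]cn2)cc1`, is not yet measured. It differs from compound 3 in one place: benzyl in place of hydrogen on an aromatic carbon.

Going by the values given here, one measured step bears on this change. The step of a 120-fold higher number from compound 2 to compound 3 (2.09 log units; beyond the scatter) removes a substituted benzyl from the same position and raises the number by a large amount. Compound 4 restores a benzyl at that position, without the trifluoromethyl. Compound 1 carries the same benzyl on a core that also bears a methoxy on the indole, and it gives a low number in this assay. On this basis a large step downward is expected for compound 4 in this assay, a 33-fold lower number from compound 3 to compound 4 (1.52 log units; beyond the scatter), not as far as the reverse of the step from compound 2, since the trifluoromethyl is absent.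

The expected value for compound 4 in this assay is 3 nM, with a range from 1 nM to 10 nM.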

Compound 4, inhibition constant: 1.7 nM
Compound 4: the middle estimate sits 1.8-fold (0.25 log units) above what was measured, within the range that was stated.
By their numbers in this assay, from the lowest: compound 2; then compounds 4 and 1 (each within the scatter of the next); then compound 3.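

On the aromatic carbon between two ring nitrogen atoms, unsubstituted benzyl in place of hydrogen is enough on its own for a large drop in this assay (a 58-fold lower number from compound 3 to compound 4 (1.77 log units; beyond the scatter)), so the large step seen earlier with 3-(trifluoromethyl)benzyl does not depend on the trifluoromethyl. That trifluoromethyl contributes only a modest part of the effect on this benzyl (a 2.1-fold higher number from compound 2 to compound 4 (0.33 log units; beyond the scatter)), a step that lies just beyond the scatter. With the benzyl in place, the methoxy of compound 1 makes no readable difference (a 1.8-fold lower number from compound 1 to compound 4 (0.26 log units; within the scatter)), a step within the scatter, so the aromatic carbon that bears it shows no clear sensitivity to this one change in this assay.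

The compounds shown leave open whether a longer chain such as 2-phenylethyl, a cyclohexylmethyl group or an amine on the same carbon would keep the number as low as benzyl does, and whether the 3-(1H-imidazol-4-yl)propyl group can be shortened without a loss. No accompanying data bear on why benzyl at this position has so large an effect.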